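Shortening a Side Chain and Cytotoxicity Toward Macrophages

The source may hold more compounds than are shown below. What is called first, only, known or untested is meant among the compounds shown, and "the series" means these compounds.

Of the compounds shown here, three have been measured in an ADME assay on J774.1 cells (Mus musculus) for cytotoxicity, with a stated time of 48 h; on this read-out lower numbers stand for an effect already at smaller amounts and higher numbers for an effect only at larger amounts of compound. Compound 1, `COC(=O)C1C(=O)C(C(=O)OC)[C@H](c2ccccn2)N(CCCCCCCC(=O)O)[C@@H]1c1ccccn1`, gives 33.8 uM in this assay. Going by the values given here, compound 2, `COC(=O)C1C(=O)C(C(=O)OC)[C@H](c2cccc([N+](=O)[O-])c2)N(Cc2ccc(C)cc2)[C@@H]1c1cccc([N+](=O)[O-])c1`, gives 49.8 uM in this assay, a number that lies within the scatter of the one for compound 1. Compound 3, `CC[C@@H]1CC2(C[C@@H](CC)N1)C(=O)NC(=O)N2Cc1ccccc1`, returns only a limit of > 100 uM in this assay. Of the two values that are numbers, compound 1 holds the lower one, but since its gap to compound 2 is within the scatter, neither compound can be called the more cytotoxic of the two.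

The step under consideration leads to compound 4, `COC(=O)C1C(=O)C(C(=O)OC)[C@H](c2ccccn2)N(CCCO)[C@@H]1c1ccccn1`, which has not yet been measured. It differs from compound 1 in one place: hydroxy in place of 4-carboxybutyl on a saturated chain carbon, three bonds along the chain from an amine nitrogen in a ring. The rest of compound 1 is unchanged.

Among the compounds with values here, no measured pair shows what this kind of shortening does in this assay, so the expectation rests on the number for compound 1 alone. The estimated step from compound 1 to compound 4 is a 1.2-fold higher number from compound 1 to compound 4 (0.07 log units; within the scatter), a change expected to fall within or only just beyond the scatter. Compound 4 is expected to give about 40 uM in this assay, within a range from 15 uM to 100 uM.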

Compound 4, concentration for half-maximal effect: 32 uM
The estimate for compound 4 lay 1.3-fold (0.10 log units) above the measured number; measured number inside the range.
By their numbers in this assay, from the lowest: compounds 4, 1 and 2 (each within the scatter of the next). At a limit, above all of these: compound 3.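

Until now, no measured pair had shown what happens at this position, on a saturated chain carbon, three bonds along the chain from an amine nitrogen in a ring. Replacing 4-carboxybutyl with hydroxy gives a 1.1-fold lower number from compound 1 to compound 4 (0.02 log units; within the scatter) in this assay, so this read-out does not separate the long chain ending in a carboxy group from the short chain ending in hydroxy on the core of compound 1. Thus, for this one pair, neither the carboxy end nor the length of the chain shows up in the number, though nothing shown accounts for this result.

A single pair cannot show whether the hydroxy end of the short chain and the carboxy end of the long one matter separately, and a plain alkyl chain, an amine at the chain end, or a longer chain ending in hydroxy at this position could each behave differently. From the compounds shown here alone, it also remains open whether the same exchange would give a similar step on a core carrying other aryl groups, such as the nitrophenyl groups of compound 2.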